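Trifluoromethoxy replacing hydrogen on the anilino ring of compound 1

The source may report more compounds than this note shows. Statements on the series, on what has been measured and on what is new or still open speak of the compounds shown alone.

Compound 1 `Fc1ccccc1Nc1nc2nonc2nc1Nc1ccccc1` is the weaker of the two measured compounds in an assay on mitochondria from L6 cells (Rattus norvegicus) for activation, with a stated time of 90 min (a higher number here means that more compound is needed for the effect, a lower number that less compound is needed), where compound 1 gives 2200 nM. For the measured compounds named here, its only measured neighbour, compound 2 `COc1cccc(Nc2nc3nonc3nc2Nc2ccccc2F)c1`, gives 830 nM in this assay, and the single measured step, a 2.7-fold lower number from compound 1 to compound 2 (0.42 log units; beyond the scatter), is the one comparison available. Compound 3 `Fc1ccccc1Nc1nc2nonc2nc1Nc1ccc(OC(F)(F)F)cc1` has not yet been measured; it differs from compound 1 by trifluoromethoxy in place of hydrogen on an aromatic carbon. The step to compound 2 bears on this change only loosely, since both enter an oxygen-linked group on the same ring in place of hydrogen, yet the entering groups are not the same. On that basis a modest drop in this assay is expected, of roughly a 2.0-fold lower number from compound 1 to compound 3 (0.30 log units; within the scatter). The estimate for compound 3 is 1100 nM, with a range from 400 nM to 3000 nM.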

Compound 3, half-maximal effective concentration: 1300 nM
For compound 3 the middle estimate is 1.2-fold (0.07 log units) below the measured one; low and high end bracket the measured number.
By their numbers in this assay, from the lowest: compounds 2, 3 and 1 (each within the scatter of the next, the first and the last beyond it).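

In this assay the new step is a 1.7-fold lower number from compound 1 to compound 3 (0.23 log units; within the scatter), so trifluoromethoxy, with its 5 heavy atoms, can sit on this aromatic carbon, para to a large group, without moving the number beyond the scatter of compound 1. The earlier compounds shown here offered only the methoxy step, a 2.7-fold lower number from compound 1 to compound 2 (0.42 log units; beyond the scatter), and so could not show that an oxygen-linked group on this ring can leave the number within the scatter. Nothing measured here offers an explanation for this result.

From the compounds shown here alone, whether an amine or a carboxylic acid on this same carbon would move the number beyond the scatter remains open. So does whether methoxy and trifluoromethoxy would differ if each stood on the same carbon of the ring.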